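The compounds below may be only part of what the source reports. "The series", "measured", "known", "first", "only" and "open" are said of these compounds alone.

Measured compounds in an assay on isolated protein for displacement of a labelled ligand from metabotropic glutamate receptor 5 (Rattus norvegicus); on this read-out higher numbers stand for weaker inhibition and lower numbers for stronger inhibition:

- compound 1 `O=C(Nc1cccc(Cl)c1)O/N=C(\C1CCCCC1)C(Cn1ccnc1)C1CCCCC1`: 10.8 nM; 8.78 nM; 1000 nM (3 entries)
- compound 2 `Cc1nccn1CC(/C(=N/OC(=O)Nc1cccc(Cl)c1)C1CCCCC1)C1CCCCC1`: > 1000 nM
- compound 3 `O=C(Nc1cccc(Cl)c1)O/N=C(\C1CCCCC1)C(Cc1ccccn1)C1CCCCC1`: 40.4 nM

Compound 3 is the only one of the three with a single plain number in this assay. Compound 2 gives only a limit in this assay, > 1000 nM, and no number. Compound 1 has several entries, recorded as the several entries of compound 1 in this assay, 10.8 nM; 8.78 nM; 1000 nM (3 entries), which do not settle on one value.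

Compound 4 `O=C(Nc1cccc(Cl)c1)O/N=C(\C1CCCCC1)C(Cc1cc[nH]c1)C1CCCCC1` differs from compound 3 by 1H-pyrrol-3-yl in place of pyridin-2-yl on a saturated chain carbon, two bonds along the chain from a carbon with a double bond to nitrogen and a saturated ring carbon. For the measured compounds named here, the one measured step at the same place is an at least 24-fold lower number from compound 2 to compound 3 (1.39 log units; beyond the scatter), a large change; its size rests on (the limit of > 1000 nM in this assay, at which 1 of the 3 values shown sits), so the true step there is not pinned down. Both the imidazole of compound 1 and the pyridine of compound 3 sit in the two-digit range, while the 2-methylimidazole of compound 2 is off the scale, so the ring at this position clearly matters, yet no shown step tells how a pyrrole behaves. A modest loss is expected for compound 4, a 3.0-fold higher number from compound 3 to compound 4 (0.47 log units; beyond the scatter), giving an estimated 120 nM with a range from 20 nM to 800 nM in this assay.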

Compound 4, inhibition constant: 16.1 nM
Estimate against measurement, compound 4: 7.5-fold (0.87 log units) above; measured number below the stated range.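

In this assay, 1H-pyrrol-3-yl in place of pyridin-2-yl gives a 2.5-fold lower number from compound 3 to compound 4 (0.40 log units; beyond the scatter), so a ring with a hydrogen-bond donor and no hydrogen-bond acceptor is accepted on this saturated chain carbon, and the acceptor of pyridin-2-yl is not needed for a number in this range. Against 2-methyl-1H-imidazol-1-yl the same ring gives an at least 62-fold lower number from compound 2 to compound 4 (1.79 log units; beyond the scatter), but compound 2 offers only a limit, so this step has no fixed size: the limit of > 1000 nM in this assay, at which 1 of the 4 values shown sits. Compound 1 cannot be read against compound 4, as its entries do not settle on one value: the several entries of compound 1 in this assay, 10.8 nM; 8.78 nM; 1000 nM (3 entries)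

From the compounds shown here alone, whether the hydrogen on the pyrrole nitrogen contributes at all stays open, and a methyl on that nitrogen would bear on this. A plain phenyl at the same place would show whether any ring nitrogen is needed.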